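The compounds below may be only part of what the source reports. "The series", "measured", "known", "first", "only" and "open" are said of these compounds alone.

Measured so far in an ADME assay on MDA-MB-231 cells (Homo sapiens) for inhibition, read by MTT assay, with a stated time of 24 h; a lower number here means a stronger inhibitor, a higher number a weaker inhibitor:
compound 1 `CC(C)=CCC[C@H](C)c1ccc(C)c2c1OCN(CC1CCNCC1)C2`: > 20000 nM
compound 2 `CC(C)=CCC[C@H](C)c1ccc(C)c2c1OCN(CCCCCO)C2`: > 20000 nM
compound 3 `CC(C)=CCC[C@H](C)c1ccc(C)c(CNCCCCCO)c1O`: > 20000 nM

Each of these entries is a limit of the test and not a true number. In this assay, compound 2 gives > 20000 nM, which is a limit. It has no rank among the three, and the series as a whole stands at the limit of > 20000 nM in this assay, at which 3 of the 3 values shown sit. No true strength is known for any of these compounds.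

The next compound, compound 4 `CC(C)=CCC[C@H](C)c1ccc(C)c2c1OCN(CCCCC(=O)O)C2`, keeps the shared core of compound 2 and changes only the end of its chain: carboxy in place of hydroxymethyl on a saturated chain carbon, four bonds along the chain from an amine nitrogen in a ring.

For the measured compounds named here, only one measured step touches this chain: a step that the two limits leave unreadable from compound 1 to compound 2. With no readable size, it offers nothing to carry over to the new change, and no direction can be argued from it. The expectation therefore rests on compound 2 itself, with its limit of > 20000 nM.

No change beyond the usual scatter is expected, and the estimated step is a step that the limit leaves unreadable from compound 2 to compound 4. Another reading at the limit is the most likely result. In this assay, the estimate for compound 4 is 25000 nM, with an expected range of 12000 nM to 50000 nM.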

Compound 4, half-maximal inhibitory concentration: > 20000 nM
Compound 4 ended at the assay's limit (the forecaster's own chance of this, stated with the estimate: 85%); the middle value lies beyond the limit too.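

Compound 4, like compound 1 and compound 2, gives only a limit in this assay, so neither step to compound 4 can be read, in size or in direction. The series now stands as follows: the limit of > 20000 nM in this assay, at which 4 of the 4 values shown sit.

What the compounds shown leave open is the true strength of each one, and whether any change to the chain alters it.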